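Shorter chain to the ((iodomethyl)carbonyl)amino end group

The source may report more compounds than this note shows. Statements on the series, on what has been measured and on what is new or still open speak of the compounds shown alone.

Compound 1 `O=C(CI)NCCCCCC(=O)NCCCCCCNc1ncnc2c1ncn2[C@@H]1O[C@H](COP(=O)(O)OP(=O)(O)OP(=O)(O)O)[C@@H](O)[C@H]1O` was run in an assay on isolated protein for inhibition of hexokinase-3 (Rattus norvegicus), with a stated time of 6 h, tested at 10 mM (a lower number here means less inhibition, a higher number more inhibition at the concentration tested (going by the name of the read-out)), where compound 1 gives 0%. Compound 2 `CN(CCCN(C)C(=O)CCCCNc1ncnc2c1ncn2[C@@H]1O[C@H](COP(=O)(O)OP(=O)(O)OP(=O)(O)O)[C@@H](O)[C@H]1O)C(=O)CCCCNC(=O)CI` carries a differently built chain on the same core, and in this assay compound 2 gives 0%. Compound 1 stands level with compound 2 at the digits recorded; the two values fall within the scatter, so no order or change between them can be read. Within the data shown here, no step between measured compounds that differ in one place is available for this series.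

Compound 3 `O=C(CI)NCCC(=O)NCCCCCCNc1ncnc2c1ncn2[C@@H]1O[C@H](COP(=O)(O)OP(=O)(O)OP(=O)(O)O)[C@@H](O)[C@H]1O` differs from compound 1 by ((iodomethyl)carbonyl)amino in place of 3-(((iodomethyl)carbonyl)amino)propyl on a saturated chain carbon, two bonds along the chain from a carbonyl carbon. Among the measured compounds shown here, nothing among the measured compounds links the length of this chain to the read-out, and both measured compounds show no inhibition at the digits recorded. The expected step is no change at the digits printed from compound 1 to compound 3 (within the scatter), nothing beyond the scatter. Compound 3 is therefore estimated at 0% in this assay, with a range from 0% to 10%.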

Compound 3, a percentage reported as inhibition, at one concentration (the size of the read-out at that concentration, not a potency): 0%
Beside the measured number, compound 3's estimate shows no gap at the digits printed; measured number inside the range.
By their numbers in this assay, from the lowest: compounds 1, 2 and 3 (each within the scatter of the next).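

In this assay, among these compounds, putting ((iodomethyl)carbonyl)amino in place of 3-(((iodomethyl)carbonyl)amino)propyl on a saturated chain carbon, two bonds along the chain from a carbonyl carbon, gives no change at the digits printed from compound 1 to compound 3 (within the scatter), the first step that changes one place only. This shorter chain to the end group does not bring inhibition into view at the single concentration tested, and with compound 1 at 0% the step could only have shown a gain, not a loss. No supporting data bear on this flat result.

From the compounds shown here alone, whether a longer chain, such as 7-(((iodomethyl)carbonyl)amino)heptyl, would lift the read-out stays open. Also open, going by these compounds, is whether another end group on the same chain, such as a chloroacetamide or a free amine, would do so.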